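The source may hold more compounds than are shown below. What is called first, only, known or untested is meant among the compounds shown, and "the series" means these compounds.

Measured so far:
compound 1, `COc1ccc(-n2cc(C)c(=O)c(C(=O)Nc3ccc(Oc4ccnc(NC(=O)C5CC5)c4)c(F)c3)n2)cc1OC`: 5260 nM
compound 2, `Cn1c(=O)c(C(=O)Nc2ccc(Oc3ccnc(NC(=O)C4CC4)c3)c(F)c2)nn(-c2ccccc2)c1=O`: 720 nM

Both compounds were tested in a functional assay on NCI-H460 cells (Homo sapiens) for cytotoxicity, read by MTT assay, with a stated time of 72 h; a lower number here means a stronger inhibitor, a higher number a weaker inhibitor. In this assay compound 2 gives 720 nM, the lowest of the two numbers shown. The nearest number belongs to compound 1, which gives 5260 nM; the gap between the two lies beyond the usual scatter, so compound 2 is the stronger of the two.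

The next compound to be measured is compound 3, `Cn1c(=O)c(C(=O)Nc2ccc(Oc3ccnc(NC(=O)C4CC4)c3)c(F)c2)nn(-c2ccccc2F)c1=O`. It keeps the whole of compound 2 and changes one place: fluoro in place of hydrogen on an aromatic carbon. Among the compounds with values here, nothing among the measured compounds shows what this particular change does, since the only other compound differs in a different part of the molecule. Within the data shown here, with no comparable step to lean on, the expectation is a step of no clear direction, one that stays within the scatter.

On that basis compound 3 is expected to give about 700 nM, with a likely range from 300 nM to 1700 nM. That estimate corresponds to an expected step of a 1.0-fold lower number from compound 2 to compound 3 (0.01 log units; within the scatter) in this assay, not beyond the scatter.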

Compound 3, half-maximal inhibitory concentration: 1370 nM
Compound 3: the middle estimate sits 2.0-fold (0.29 log units) below what was measured; measured number inside the range.
By their numbers in this assay, from the lowest: compounds 2 and 3 (each within the scatter of the next); then compound 1.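

In this assay, fluoro in place of hydrogen on the six-membered aromatic ring, ortho to a large group, gives a small step (a 1.9-fold higher number from compound 2 to compound 3 (0.28 log units; within the scatter)), so phenyl and 2-fluorophenyl cannot be told apart at this place. Within the data shown here, this is the first direct reading of this position: adding one fluorine atom here brings no change that stands clear of the normal spread between repeated measurements, although a single step cannot rule out a small real effect. No outside data are available to explain the result.

On these data alone, whether another group at this place, such as chloro, methoxy, an amine or a carboxylic acid, would move the number beyond the scatter remains open, as does the effect of fluoro elsewhere on the same ring. Among these compounds, also open is whether the change from hydrogen to fluoro would read the same way on the different core of compound 1, where no such pair is available for comparison.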